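Trifluoromethyl in Place of Methoxy: Forecast for Compound 4

The compounds below may be only part of what the source reports. "The series", "measured", "known", "first", "only" and "open" are said of these compounds alone.

Three compounds have been examined in a functional assay on NIH3T3 cells for agonist activity at Urotensin-2 receptor (Homo sapiens), with a stated time of 5 days; on this read-out lower numbers stand for an effect already at smaller amounts and higher numbers for an effect only at larger amounts of compound. Compound 1 `CN(C)CCC(NC(=O)/C=C/c1ccc(C(F)(F)F)cc1)c1ccc2ccccc2c1` gives 135 nM, compound 2 `COc1ccc(/C=C/C(=O)NC(CCN(C)C)c2ccc(C)cc2)cc1` gives 2000 nM, and compound 3 `COc1ccc(/C=C/C(=O)NC(CCN(C)C)c2ccc(Cl)cc2)cc1` gives 513 nM. Compound 2 thus carries the highest number of the three; the nearest is compound 3, reached by a 3.9-fold lower number from compound 2 to compound 3 (0.59 log units; beyond the scatter) through chloro in place of methyl on an aromatic carbon, while compound 1 sits furthest away, as its value shows. Compound 4 `Cc1ccc(C(CCN(C)C)NC(=O)/C=C/c2ccc(C(F)(F)F)cc2)cc1` differs from compound 2 by trifluoromethyl in place of methoxy on an aromatic carbon. Going by the values given here, the only measured step, a 3.9-fold lower number from compound 2 to compound 3 (0.59 log units; beyond the scatter), concerns the other ring and bears only loosely on this change; compound 1, which also carries trifluoromethyl, shows the lowest value. The expectation is therefore a 3.3-fold lower number from compound 2 to compound 4 (0.52 log units; beyond the scatter) in this assay, putting compound 4 at an estimated 600 nM, with a range from 200 nM to 2500 nM.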

Compound 4, half-maximal effective concentration: 437 nM
For compound 4 the middle estimate is 1.4-fold (0.14 log units) above the measured one; the range from low to high includes it.
By their numbers in this assay, from the lowest: compound 1; then compounds 4 and 3 (each within the scatter of the next); then compound 2.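

Trifluoromethyl in place of methoxy, on an aromatic carbon para to a large group, gives a 4.6-fold lower number from compound 2 to compound 4 (0.66 log units; beyond the scatter) and so provides the first direct measurement of a change at this position. With trifluoromethyl held in place, 4-methylphenyl in place of naphthalen-2-yl gives a 3.2-fold higher number from compound 1 to compound 4 (0.51 log units; beyond the scatter) and shows that the group on the saturated chain carbon also affects the read-out. Nothing available explains either step. The compounds shown leave open how a nitrile or a carboxylic acid would behave on this aromatic carbon.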